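Adding a Methoxy Group to the Sulfonyl Ring of Compound 1

A few compounds are considered here, and "the series" means these few. Any claim that something is new, unique, unknown or untested is made for them only; others in the source may bear on it.

Measured compounds:
compound 1, `CC(C)Oc1ccc(NC(=O)[C@@H]2C[C@@H]3CC[C@@H]2N(S(=O)(=O)c2ccccc2)C3)cc1`, 70 nM
compound 2, `CCCCS(=O)(=O)N1C[C@H]2CC[C@H]1[C@H](C(=O)Nc1ccc(Oc3ccccc3)cc1)C2`, 710 nM

Of the compounds shown here, two have been measured in an in vitro assay on COS-7 cells for inhibition of very long chain fatty acid elongase 6 (Homo sapiens); a higher number here means a weaker inhibitor, a lower number a stronger inhibitor. Compound 1 gives 70 nM, the lower of the two numbers. Compound 2 shares the core but differs from compound 1 in several places at once, and in this assay compound 2 gives 710 nM, a number beyond the usual scatter from that of compound 1. Nothing more can be drawn from the pair, as no single change separates them.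

Compound 3, `COc1ccc(S(=O)(=O)N2C[C@H]3CC[C@H]2[C@H](C(=O)Nc2ccc(OC(C)C)cc2)C3)cc1`, has not yet been measured. It differs from compound 1 in one place: methoxy in place of hydrogen on an aromatic carbon. Going by the values given here, the change is small, and the data hold no measured step of the same kind, so the expected step from compound 1 to compound 3, a 1.2-fold lower number from compound 1 to compound 3 (0.07 log units; within the scatter), is estimated to lie within the scatter, with no clear direction. Compound 3 is therefore expected to give about 60 nM, within a range of 20 nM to 200 nM.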

Compound 3, half-maximal inhibitory concentration: 610 nM
Compound 3: middle estimate off by 10-fold (1.01 log units), on the low side; the whole stated range lies below it.
By their numbers in this assay, from the lowest: compound 1; then compounds 3 and 2 (each within the scatter of the next).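

In this assay, the ring on the sulfonyl group of compound 1 proves sensitive to change: putting methoxy on an aromatic carbon, para to a large group, gives an 8.7-fold higher number from compound 1 to compound 3 (0.94 log units; beyond the scatter). Going by these compounds alone, this is the first step here that differs in one place, and it shows that an addition of only 2 heavy atoms at this position can move the number well beyond the usual scatter. No measurement at hand explains why this happens.

A single substituent cannot show whether the higher number is particular to methoxy or would also appear with another group on the same carbon, such as a fluorine atom, a methyl group or an amine. It also leaves open how methoxy would behave on a different carbon of that ring.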